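Taking the methylsulfanyl group off compound 2

This account rests on a few compounds, and the source may have more. Where it says the series, first, only, none or still open, it means among the compounds named here.

Compound 1 `COc1cc(O)c(C(=O)/C=C/c2ccc(F)cc2)c(OC)c1` gives 5400 nM
Compound 2 `COc1cc(OC)c(C(=O)/C=C/c2ccccc2SC)c(OC)c1` gives 8300 nM

In a functional assay on RL cells (Homo sapiens) for cytotoxicity, with a stated time of 48 h (on this read-out higher numbers stand for weaker inhibition and lower numbers for stronger inhibition), compound 2 gives 8300 nM and stands within the usual scatter of compound 1 at 5400 nM on this read-out. Compound 3 `COc1cc(OC)c(C(=O)/C=C/c2ccccc2)c(OC)c1` has hydrogen in place of methylsulfanyl on an aromatic carbon, ortho to a large group (hydrogen in place of methylsulfanyl on an aromatic carbon). For the measured compounds named here, no measured pair shows this change, so the data offer no direct guide. No step beyond the scatter is expected in this assay in either direction. The estimated step is small (a 1.2-fold lower number from compound 2 to compound 3 (0.07 log units; within the scatter)). Compound 3 is expected at 7000 nM (estimated range 2500 nM to 20000 nM).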

Compound 3, half-maximal inhibitory concentration: 6900 nM
The estimate for compound 3 lay 1.0-fold (0.01 log units) above the measured number, and the stated range covers the measured number.
By their numbers in this assay, from the lowest: compounds 1, 3 and 2 (each within the scatter of the next).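

In this assay, the exchange of methylsulfanyl for hydrogen on this aromatic carbon, ortho to a large group, gives a 1.2-fold lower number from compound 2 to compound 3 (0.08 log units; within the scatter). For the compounds shown here, this is the first direct reading of this position, and it shows that, in this pair, the methylsulfanyl group can be removed without a step beyond the scatter. The data at hand offer no explanation for this result. On these data alone, whether an amine or a carboxylic acid on this carbon would give a step beyond the scatter remains open, as does whether the same exchange would behave alike on another core.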